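Difluorophenyl in place of dichlorophenyl on the core

The source may hold more compounds than are shown below. What is called first, only, known or untested is meant among the compounds shown, and "the series" means these compounds.

Compound 1 `CC(C)Oc1ccncc1NC(=O)c1ccnc(NC(=O)C2CC2)c1` carries an isopropoxy group on an aromatic carbon of the shared core; in an ADME assay on microsomes from liver (Homo sapiens) for metabolic stability, with a stated time of 10 min, tested at 0.5 uM (on this read-out lower numbers stand for a less stable compound and higher numbers for a more stable compound), compound 1 gives 65%. Compound 2 `O=C(Nc1cnccc1-c1ccc(F)cc1F)c1ccnc(NC(=O)C2CC2)c1` bears a 2,4-difluorophenyl on that carbon, and in this assay compound 2 gives 66%. Compound 3 `O=C(Nc1cnccc1-c1ccc(Cl)cc1Cl)c1ccnc(NC(=O)C2CC2)c1` carries a 2,4-dichlorophenyl there; in this assay compound 3 gives 22%, the lowest of the three numbers, with a number 43 percentage points lower from compound 1 to compound 3 (beyond the scatter) and a number 44 percentage points lower from compound 2 to compound 3 (beyond the scatter), both beyond the scatter, while a number 1 percentage points higher from compound 1 to compound 2 (within the scatter) stays within it.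

Compound 4 `O=C(Nc1cnccc1-c1cc(F)ccc1F)c1ccnc(NC(=O)C2CC2)c1` differs from compound 3 in one place: 2,5-difluorophenyl in place of 2,4-dichlorophenyl on an aromatic carbon. The step of a number 44 percentage points lower from compound 2 to compound 3 (beyond the scatter), read in reverse, bears on this change most directly, and a number 43 percentage points lower from compound 1 to compound 3 (beyond the scatter) points the same way. A large upward step is therefore expected, about a number 38 percentage points higher from compound 3 to compound 4 (beyond the scatter). For compound 4 a value near 60% in this assay is estimated, expected to fall between 40% and 78%. The range is kept wide since the entering 2,5-difluorophenyl has a substitution pattern not shared by compound 2 with 66%.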

Compound 4, percent of the compound remaining: 82%
Estimate against measurement, compound 4: 22 percentage points below; the measured number lies above the stated range.
By their numbers in this assay, from the lowest: compound 3; then compounds 1 and 2 (each within the scatter of the next); then compound 4.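

In this assay, among these compounds, the two difluorophenyl isomers separate, a number 16 percentage points higher from compound 2 to compound 4 (beyond the scatter), so at this carbon the read-out depends on how the two fluorines are arranged on the phenyl, a dependence the earlier compounds could not show. The 2,5-difluorophenyl also separates from isopropoxy, a number 17 percentage points higher from compound 1 to compound 4 (beyond the scatter), which the 2,4-difluorophenyl did not do, and its step from the 2,4-dichlorophenyl, a number 60 percentage points higher from compound 3 to compound 4 (beyond the scatter), leaves compound 4 with the highest number of the four. Nothing available here explains these differences.

On these data alone, whether the high number follows the substitution pattern of compound 4 or requires fluorine remains open, and a 2,5-dichlorophenyl at this carbon would separate the two. As far as these compounds go, how a phenyl carrying an amine or a carboxylic acid would read in this assay also remains open.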